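The source may hold more compounds than are shown below. What is called first, only, known or untested is meant among the compounds shown, and "the series" means these compounds.

In an ADME assay on MRC5 cells (Homo sapiens) for inhibition, with a stated time of 72 h (a lower number here means that less compound is needed, a higher number that more compound is needed for the effect), three compounds share one core and differ only in the group on a carbonyl carbon. Compound 1 `COc1cccc(OC)c1C(=O)Nc1c[nH]nc1C(=O)NN1CCOCC1` carries (morpholin-4-yl)amino there, and its reading of > 50000 nM is a limit of the assay, not a number. Compound 2 `COc1cccc(OC)c1C(=O)Nc1c[nH]nc1C(=O)O` carries hydroxy, and its reading of > 50000 nM is also a limit. Among the measured compounds shown here, compound 3 `COc1cccc(OC)c1C(=O)Nc1c[nH]nc1C(=O)NC1CCCCCC1` carries cycloheptylamino and gives 42000 nM, the only actual number among the three.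

The next compound alters only the ring of that group. Compound 4 `COc1cccc(OC)c1C(=O)Nc1c[nH]nc1C(=O)NC1CCCCC1` differs from compound 3 as follows: cyclohexyl in place of cycloheptyl on an amide-type nitrogen.

Two measured steps change the group at this same place: an at least 1.1-fold lower number from compound 1 to compound 3 (0.07 log units; that floor lies within the scatter), and an at least 1.1-fold lower number from compound 2 to compound 3 (0.07 log units; that floor lies within the scatter). Both are only floors, and both stay within the scatter, so neither shows a firm difference. The swap of cycloheptyl for cyclohexyl is therefore not expected to produce a step beyond the scatter in this assay, in either direction. The readings so far also stand against (the limit of > 50000 nM in this assay, at which 2 of the 3 values shown sit), so compound 4 may well return a limit rather than a number. The expected change is a 1.1-fold higher number from compound 3 to compound 4 (0.03 log units; within the scatter), which would lie within the scatter. The estimated value for compound 4 is 45000 nM, with an expected range from 20000 nM to 80000 nM.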

Compound 4, half-maximal effective concentration: 35000 nM
Beside the measured number, compound 4's estimate is 1.3-fold (0.11 log units) above it; the measured number falls inside the stated range.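

In this assay the ring on the amide-type nitrogen can go from cycloheptyl to cyclohexyl with a 1.2-fold lower number from compound 3 to compound 4 (0.08 log units; within the scatter) as the result, so these two all-carbon rings cannot be told apart here. Compound 4 also gives this position a second actual number: compounds 3 and 4, with an all-carbon ring on that nitrogen, both give numbers, whereas compound 1 with morpholin-4-yl and compound 2 with hydroxy in place of the amine-linked ring give only limits. The comparisons with those two compounds are (an at least 1.4-fold lower number from compound 2 to compound 4 (0.15 log units; that floor lies within the scatter)) and (an at least 1.4-fold lower number from compound 1 to compound 4 (0.15 log units; that floor lies within the scatter)), and these are only floors, so their true size cannot be read and they show no firm difference: the limit of > 50000 nM in this assay, at which 2 of the 4 values shown sit.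

The compounds shown leave open whether a smaller ring such as cyclopentyl, an open chain such as n-hexyl or a flat phenyl ring on the same nitrogen would move the number beyond the scatter. On these data alone, it also remains open whether a ring carrying a basic amine, such as piperidin-4-yl, would give a number or another limit.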